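The source may hold more compounds than are shown below. What is called first, only, known or untested is meant among the compounds shown, and "the series" means these compounds.

Working notes on the series. Compound 1 `COc1ccc(C2=NN(C3=NC(=O)/C(=C4\C(=O)Nc5ccccc54)S3)C(c3ccc(OC)cc3)C2)cc1` gives 85200 nM in a functional assay on cells (Cancer cell lines, Homo sapiens) for cytotoxicity, read by sulforhodamine B assay, with a stated time of 48 h; on this read-out higher numbers stand for weaker inhibition of growth and lower numbers for stronger inhibition of growth. Compound 2 `COc1ccc(C2CC(c3ccc4ccccc4c3)=NN2C2=NC(=O)/C(=C3\C(=O)Nc4ccccc43)S2)cc1` gives 870 nM in this assay. Compound 3 `COc1ccc(C2=NN(C3=NC(=O)/C(=C4\C(=O)Nc5ccccc54)S3)C(c3ccc(Cl)cc3)C2)cc1` gives 100000 nM in this assay, the highest of the three numbers. The cores of compound 1 and compound 3 differ by chloro in place of methoxy on an aromatic carbon, and the step of a 1.2-fold higher number from compound 1 to compound 3 (0.07 log units; within the scatter) lies within the scatter. The change naphthalen-2-yl in place of 4-methoxyphenyl on a carbon with a double bond to nitrogen produced a 98-fold lower number from compound 1 to compound 2 (1.99 log units; beyond the scatter).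

Compound 4 `O=C1N=C(N2N=C(c3ccc4ccccc4c3)CC2c2ccc(Cl)cc2)S/C1=C1/C(=O)Nc2ccccc21` is not yet measured; it differs from compound 3 by naphthalen-2-yl in place of 4-methoxyphenyl on a carbon with a double bond to nitrogen. Within the data shown here, this is the same kind of change as the one from compound 1 to compound 2, not the same: around the place, the ring atom two ring bonds away bears a 4-chlorophenyl group in compound 3 where it bears a 4-methoxyphenyl group in compound 1. The change occurs twice among the compounds shown.

For compound 4 the expected step in this assay is an 83-fold lower number from compound 3 to compound 4 (1.92 log units; beyond the scatter), resting on a 98-fold lower number from compound 1 to compound 2 (1.99 log units; beyond the scatter) alone, one earlier example. Compound 4 is thus estimated at 1200 nM, between 300 nM and 6000 nM.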

Compound 4, concentration for 50% growth inhibition: 400 nM
Compound 4: the middle estimate sits 3.0-fold (0.48 log units) above what was measured; low and high end bracket the measured number.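

In this assay the replacement of 4-methoxyphenyl by naphthalen-2-yl carries over to the core bearing the 4-chlorophenyl group, with a 250-fold lower number from compound 3 to compound 4 (2.40 log units; beyond the scatter), and the two examples do not differ beyond the scatter: the same change on two cores in this assay, a 98-fold lower number (1.99 log units; beyond the scatter) from compound 1 to compound 2 and a 250-fold lower number (2.40 log units; beyond the scatter) from compound 3 to compound 4, 2.6-fold (0.41 log units) apart, within the scatter of two such steps. Chloro in place of methoxy gives a 2.2-fold lower number from compound 2 to compound 4 (0.34 log units; beyond the scatter) on the core carrying naphthalen-2-yl, a modest step, yet its gap from the earlier example also stays within the scatter: the same change on two cores in this assay, a 1.2-fold higher number (0.07 log units; within the scatter) from compound 1 to compound 3 and a 2.2-fold lower number (0.34 log units; beyond the scatter) from compound 2 to compound 4, 2.6-fold (0.41 log units) apart, within the scatter of two such steps. Among these compounds, this supports carrying each change between these two cores, but with only one pair per core it does not show that either step would hold on any other core, nor does it explain the size of the naphthalen-2-yl step.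

The compounds shown leave open whether a methyl group, or a phenyl ring carrying an amine or a carboxylic acid, on the carbon with a double bond to nitrogen would keep the low numbers of compound 2 and compound 4. Going by these compounds, it also remains open whether a fluoro or nitrile group in place of the chloro would fit the same picture.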